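The source may hold more compounds than are shown below. What is called first, only, known or untested is meant among the compounds shown, and "the series" means these compounds.

In an assay on isolated protein for inhibition of polyamine deacetylase HDAC10 (Homo sapiens), read by fluorescence, tested at 100 uM (on this read-out lower numbers stand for less inhibition and higher numbers for more inhibition at the one concentration tested (going by the name of the read-out)), compound 1 `O=C(NC(=S)NCc1ccccc1)c1ccccc1` was reported as "not active" (no number reported), with no number attached, so no single value fixes where it stands. Compound 2 `O=C(NC(=S)NCc1ccccc1)c1ccccc1F`, a close relative, gives 5% in this assay, which amounts to almost no inhibition. Compound 3 `O=C(NC(=S)NCc1ccc(-c2ccccc2)cc1)c1ccccc1` differs from compound 1 by phenyl in place of hydrogen on an aromatic carbon. Within the data shown here, no measured pair shows what this kind of change does here, so the step is expected to be small, most likely within the usual scatter, with no clear direction. Compound 3 is therefore estimated to give 8% in this assay, within a range of 0% to 25%.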

Compound 3, a percentage reported as inhibition, at one concentration (the size of the read-out at that concentration, not a potency): 5%
For compound 3 the middle estimate is 3 percentage points above the measured one; low and high end bracket the measured number.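

Among these compounds, compound 1 carries no number, so no step to compound 3 can be read. Going by these compounds, whether phenyl in place of hydrogen changes inhibition at all stays open. No further evidence bears on this result.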